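Swapping chloro for methoxy on a weakly active compound

The compounds below may be only part of what the source reports. "The series", "measured", "known", "first", "only" and "open" are said of these compounds alone.

In a functional assay on MDA-MB-231 cells (Homo sapiens) for antiproliferative activity, read by sulforhodamine B assay, with a stated time of 72 h (a higher number here means a weaker inhibitor, a lower number a stronger inhibitor), compound 2 `O=C(/C=C/c1cc2ccccc2s1)c1cc(Cl)ccc1O` gives > 10000 nM, which is a limit of the assay and not a number. Compound 3 `O=C(/C=C/c1cc2ccccc2s1)c1cc(Cl)cc(Cl)c1O` gives 7500 nM. Compound 1 `COc1cc(O)c(C(=O)/C=C/c2csc3ccccc23)cc1OC` gives 690 nM.

Compound 4 `COc1ccc(O)c(C(=O)/C=C/c2cc3ccccc3s2)c1` is compound 2 with a single change, methoxy in place of chloro on an aromatic carbon. The closest measured step is an at least 1.3-fold lower number from compound 2 to compound 3 (0.12 log units; that floor lies within the scatter), where chloro takes the place of hydrogen on an aromatic carbon. That step gives only a floor and involves no methoxy, so it is a poor guide to size. Compound 1 also carries methoxy and gives 690 nM, but it differs from compound 4 elsewhere too, which makes it only a weak hint of a lower number. The expected step is therefore modest, an at least 2.0-fold lower number from compound 2 to compound 4 (0.30 log units; that floor lies within the scatter), toward a lower number. Compound 4 is expected at about 5000 nM, with an estimated range from 1500 nM to 15000 nM. A reading that is only a limit would be no surprise.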

Compound 4, half-maximal inhibitory concentration: > 10000 nM
Compound 4: only a limit was reported (the forecaster's own chance of this, stated with the estimate: 30%); middle value at least 2.0-fold (0.30 log units) from the limit.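

The step from compound 2 to compound 4, methoxy in place of chloro, cannot be read, because each compound's reading is a limit of the assay and not a number: the limit of > 10000 nM in this assay, at which 2 of the 4 values shown sit. The compounds shown leave open whether chloro or methoxy gives the lower number at this place.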